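A few compounds are considered here, and "the series" means these few. Any claim that something is new, unique, unknown or untested is made for them only; others in the source may bear on it.

Measured so far:
compound 1 `Cc1c(CO)cc2n1[C@@H](c1ccccc1)SC2` gives 4300 nM in a functional assay on MCF7 cells (Homo sapiens) for cytotoxicity, read by MTT assay, with a stated time of 48 h; a higher number here means a weaker inhibitor, a lower number a stronger inhibitor
compound 2 `Cc1c(CO)c(CO)c2n1[C@@H](c1ccccc1)SC2` gives 1900 nM in this assay

Going by the values given here, compound 2 holds the lower of the two numbers; the only step measured so far is a 2.3-fold lower number from compound 1 to compound 2 (0.35 log units; beyond the scatter). Compound 3 `OCc1c(CO)c(-c2ccc(F)cc2)n2c1CS[C@@H]2c1ccccc1` differs from compound 2 by 4-fluorophenyl in place of methyl on an aromatic carbon. Among the compounds with values here, no measured step bears on a change of this kind: the one step available concerns a hydroxymethyl group and offers no guide here. The expectation for compound 3 is therefore a step of no change at the digits printed from compound 2 to compound 3 (within the scatter), which is no shift beyond the scatter, with a wide range to reflect the lack of comparable data. Compound 3 is estimated at 1900 nM, between 600 nM and 6000 nM.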

Compound 3, half-maximal inhibitory concentration: 46300 nM
The estimate for compound 3 lay 24-fold (1.39 log units) below the measured number; measured number above the stated range.
By their numbers in this assay, from the lowest: compound 2; then compound 1; then compound 3.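

In this assay, the aromatic carbon next to the ring nitrogen proves sensitive to substitution: 4-fluorophenyl in place of methyl gives a 24-fold higher number from compound 2 to compound 3 (1.39 log units; beyond the scatter), so this methyl cannot be exchanged freely for an aromatic ring. Going by these compounds alone, this is the first large step, and it runs toward a weaker inhibitor. Nothing available gives a reason for this step.

From the compounds shown here alone, it remains open whether the six-membered aromatic ring or its fluorine drives the change. Going by these compounds, it also remains open how an ethyl or an aminomethyl group would behave on this carbon.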